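Aryl swap on the triazole in a spirooxindole series

The source may report more compounds than this note shows. Statements on the series, on what has been measured and on what is new or still open speak of the compounds shown alone.

Compound 1 `N#CC1=C(N)Oc2c(c3nc4ccccc4nc3c3ccccc23)C12C(=O)N(Cc1cnnn1-c1ccc(Cl)cc1)c1ccccc12` reaches only > 50000 nM in a functional assay on MCF7 cells (Homo sapiens) for antiproliferative activity, read by MTT assay, with a stated time of 48 h; on this read-out lower numbers stand for stronger inhibition and higher numbers for weaker inhibition. That reading is a limit of the assay, not a number: the limit of > 50000 nM in this assay, at which 1 of the 2 values shown sits. Among the measured compounds shown here, compound 2 `N#CC1=C(N)Oc2c(N)cc3nc4ccccc4nc3c2C12C(=O)N(Cc1cnnn1-c1ccccc1Br)c1ccccc12` gives 30700 nM in this assay, the single number recorded across the two measured entries. Compound 3 `N#CC1=C(N)Oc2c(N)cc3nc4ccccc4nc3c2C12C(=O)N(Cc1cnnn1-c1cc(Cl)ccc1Cl)c1ccccc12` differs by 2,5-dichlorophenyl in place of 2-bromophenyl on an aromatic nitrogen. For the measured compounds named here, no measured pair differs in one place, so the weight of this change has not been measured; no step beyond the usual scatter is expected in this assay. Compound 3 is expected near 35000 nM, within 12000 nM to 100000 nM. The step this estimate implies is a 1.1-fold higher number from compound 2 to compound 3 (0.06 log units; within the scatter). The expectation rests on compound 2 at 30700 nM.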

Compound 3, half-maximal inhibitory concentration: 33200 nM
The estimate for compound 3 lay 1.1-fold (0.02 log units) above the measured number, within the range that was stated.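

In this assay, 2,5-dichlorophenyl in place of 2-bromophenyl on an aromatic nitrogen gives a 1.1-fold higher number from compound 2 to compound 3 (0.03 log units; within the scatter). This position therefore now has one measured step, and exchanging these two halogen-bearing phenyl groups leaves the read-out within the scatter. Compound 1 stays outside this comparison, as its reading is a limit and not a number: the limit of > 50000 nM in this assay, at which 1 of the 3 values shown sits.

Still open, going by these compounds, is whether a phenyl group carrying an amine or a carboxylic acid, or a longer chain in place of the aryl ring, would shift the number at this position beyond the scatter.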